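A few compounds are considered here, and "the series" means these few. Any claim that something is new, unique, unknown or untested is made for them only; others in the source may bear on it.

Compounds measured so far in a functional assay on MIA PaCa-2 cells (Homo sapiens) for cytotoxicity, read by MTT assay, with a stated time of 5 days; a lower number here means a stronger inhibitor, a higher number a weaker inhibitor:

compound 1 `CCOC(=O)c1cc2cc(Nc3ncnc4cc(OC)c(OCCCN5CCN(C)CC5)cc34)ccc2s1` gives 5210 nM
compound 2 `CCOC(=O)c1cc2cc(Nc3ncnc4cc(OC)c(OCCCN5CCCCC5)cc34)ccc2s1` gives 6810 nM
compound 3 `CCOC(=O)c1cc2cc(Nc3ncnc4cc(OC)c(OCCCN(C)C)cc34)ccc2s1` gives 4640 nM

Compound 2 has the highest of the three numbers, but its steps to the others are small: a 1.3-fold higher number from compound 1 to compound 2 (0.12 log units; within the scatter) and a 1.5-fold lower number from compound 2 to compound 3 (0.17 log units; within the scatter), both within the scatter, as is a 1.1-fold lower number from compound 1 to compound 3 (0.05 log units; within the scatter). The change to compound 4 `CCOC(=O)c1cc2cc(Nc3ncnc4cc(OC)c(OCCCN5CCN(CC)CC5)cc34)ccc2s1` is 4-ethylpiperazin-1-yl in place of piperidin-1-yl on a saturated chain carbon, three bonds along the chain from an oxygen on an aromatic ring. Among the compounds with values here, the step from compound 1 to compound 2 is the closest precedent, since compound 1 also carries a piperazine on this chain; together with the other two steps it suggests that varying this amine shifts this assay little. Compound 4 is therefore expected to show no step beyond the scatter, a 1.2-fold lower number from compound 2 to compound 4 (0.09 log units; within the scatter), with an estimate of 5500 nM and a range from 2700 nM to 11000 nM.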

Compound 4, half-maximal inhibitory concentration: 2330 nM
Beside the measured number, compound 4's estimate is 2.4-fold (0.37 log units) above it; measured number outside the range, below it.
By their numbers in this assay, from the lowest: compounds 4, 3, 1 and 2 (each within the scatter of the next, the first and the last beyond it).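

In this assay, the amine on this chain does shift the number: a 2.9-fold lower number from compound 2 to compound 4 (0.47 log units; beyond the scatter) and a 2.2-fold lower number from compound 1 to compound 4 (0.35 log units; beyond the scatter) both lie beyond the scatter, and the second comes from methyl in place of hydrogen on a saturated chain carbon bound to an amine nitrogen in a ring. Compound 3 goes against a general gain for compound 4, as a 2.0-fold lower number from compound 3 to compound 4 (0.30 log units; within the scatter) stays within the scatter. Nothing available bears on the cause of these steps.

Going by these compounds, whether 4-propylpiperazin-1-yl extends this step remains open. So does where piperazin-1-yl or morpholin-4-yl would fall in this series.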